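From sulfamoyl to chloro: one swap, one open question

The compounds below may be only part of what the source reports. "The series", "measured", "known", "first", "only" and "open" are said of these compounds alone.

Two compounds have so far gone through an ADME assay for permeability, using PAMPA (on this read-out lower numbers stand for lower permeability and higher numbers for higher permeability), and neither gives a firm number. Compound 1 `O=C(Nc1ccc([N+](=O)[O-])cc1Cl)c1c(O)cccc1O` carries the entry "not determined" (no result reported) and offers no guide. The entry for compound 2 `NS(=O)(=O)c1ccc(NC(=O)c2cc(Cl)ccc2O)cc1` is < 1 10^-6 cm/s and this is a limit of the assay, not a number.

Compound 3 `O=C(Nc1ccc(Cl)cc1)c1cc(Cl)ccc1O` has not yet been measured. It differs from compound 2 in one place (chloro in place of sulfamoyl on an aromatic carbon), with chloro in place of sulfamoyl on an aromatic carbon, para to a large group. For the measured compounds named here, no measured pair of compounds shows what such a swap does, so any expectation here is a rough one. The expected change in this assay is a clear rise beyond the usual scatter (estimated as an at least 8.0-fold higher number from compound 2 to compound 3 (0.90 log units; beyond the scatter)). For compound 3 the estimate is 8 10^-6 cm/s (expected range 1.5 10^-6 cm/s to 30 10^-6 cm/s).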

Compound 3, apparent permeability: 297 10^-6 cm/s
Beside the measured number, compound 3's estimate is 37-fold (1.57 log units) below it; measured number above the stated range.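

Placing chloro instead of sulfamoyl on this aromatic carbon, para to a large group, gives the first measured step in the series, and it is large in this assay: an at least 290-fold higher number from compound 2 to compound 3 (2.47 log units; beyond the scatter). This shows that the read-out can respond strongly to a single change at this place, which compound 2 alone could not show. Compound 2 has only a limit, so the step has no fixed size and is open at its upper end: the limit of < 1 10^-6 cm/s in this assay, at which 1 of the 3 values shown sits.

The compounds shown do not separate the departure of sulfamoyl from the arrival of chloro. A plain hydrogen, an amine or a carboxylic acid at this same place would help to show whether the read-out follows one particular group or changes more gradually across different groups.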